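Sulfonamide series: fluoro step from compound 3 to compound 4

The compounds below may be only part of what the source reports. "The series", "measured", "known", "first", "only" and "open" are said of these compounds alone.

For the measured compounds named here, compound 3, `NS(=O)(=O)c1ccc(-n2ncc3c(=O)[nH]c(-c4ccccc4)nc32)cc1`, is one of three compounds so far measured in a functional assay on MCF7 cells (Homo sapiens) for cytotoxicity, read by MTT assay, with a stated time of 72 h; on this read-out lower numbers stand for stronger inhibition and higher numbers for weaker inhibition. In this assay compound 3 gives only a limit, > 100000 nM. Compound 1, `N#Cc1cnn(-c2ccc(S(N)(=O)=O)cc2)c1N`, likewise gives only a limit in this assay, > 100000 nM. Compound 2, `NC(=O)c1cnn(-c2ccc(S(N)(=O)=O)cc2)c1N`, also gives only a limit in this assay, > 100000 nM. Going by the values given here, the sole single-place step among the measured compounds, a step that the two limits leave unreadable from compound 1 to compound 2, is unreadable, both of its ends resting on (the limit of > 100000 nM in this assay, at which 3 of the 3 values shown sit). Compound 3 therefore stands where every measured value stands, with no number to rank it against the others.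

Compound 4, `NS(=O)(=O)c1ccc(-n2ncc3c(=O)[nH]c(-c4ccc(F)cc4)nc32)cc1`, differs from compound 3 by fluoro in place of hydrogen on an aromatic carbon of a six-membered aromatic ring of carbon only, para to a large group; cut one bond further out, phenyl to 4-fluorophenyl. Among the compounds with values here, no measured step bears on this change, and no step of readable size exists at all. The step expected from compound 3 to compound 4 in this assay is a number no higher from compound 3 to compound 4 (the limit leaves the size open), no size beyond the scatter, with a further limit the most likely outcome. Compound 4 is estimated in this assay at 100000 nM, within 30000 nM to 300000 nM.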

Compound 4, half-maximal inhibitory concentration: 38000 nM
The estimate for compound 4 lay 2.6-fold (0.42 log units) above the measured number; low and high end bracket the measured number.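

In this assay, for the compounds shown here, phenyl to 4-fluorophenyl gives an at least 2.6-fold lower number from compound 3 to compound 4 (0.42 log units; beyond the scatter), the only step that can be read, since the step between compound 1 and compound 2 cannot. This place, on a six-membered aromatic ring of carbon only and para to a large group, is therefore one where fluoro in place of hydrogen, a change of a single heavy atom, moves the read-out to a number; as compound 3 has no number of its own, the step gives only the least size of the change and not the size itself. Compound 1, compound 2 and compound 3 each remain at a limit, so this one change separates compound 4 from the rest of the series: the limit of > 100000 nM in this assay, at which 3 of the 4 values shown sit.

Still open, on these data alone, is whether the step belongs to fluoro itself or would also appear with chloro, methoxy, an amine or a carboxylic acid at the same place. Also open, as far as these compounds go, is whether a fluoro elsewhere on this ring, or a longer chain in its place, would give a number at all in this assay.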